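Methyl for Fluoro on the Benzothiazole of Compound 3

A few compounds are considered here, and "the series" means these few. Any claim that something is new, unique, unknown or untested is made for them only; others in the source may bear on it.

Compound 1 `Cc1cnc(Nc2ccc(S(C)(=O)=O)cc2)nc1Nc1nc2ccc(Cl)cc2s1` gives 13400 nM in a functional assay on PC-3 cells (Homo sapiens) for antiproliferative activity, read by MTT assay, with a stated time of 48 h; a higher number here means a weaker inhibitor, a lower number a stronger inhibitor. Compound 2 `CS(=O)(=O)c1ccc(Nc2ncc(F)c(Nc3nc4ccc(Cl)cc4s3)n2)cc1` gives > 50000 nM in this assay, which is a limit of the assay. Compound 3 `NS(=O)(=O)c1ccc(Nc2nccc(Nc3nc4ccc(F)cc4s3)n2)cc1` gives 920 nM in this assay.

Compound 3 has the lowest of the two numbers; its nearest neighbour is compound 1, with a number higher by a wide margin. One of the three values sits at the limit of > 50000 nM in this assay, at which 1 of the 3 values shown sits.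

Compound 4 `Cc1ccc2nc(Nc3ccnc(Nc4ccc(S(N)(=O)=O)cc4)n3)sc2c1` has not yet been measured in this assay. It differs from compound 3 by methyl in place of fluoro on an aromatic carbon

The same change, methyl in place of fluoro on an aromatic carbon, is seen between compounds 2 and 1, where it gave an at least 3.7-fold lower number from compound 2 to compound 1 (0.57 log units; beyond the scatter). There, however, the change sits on an aromatic carbon of a six-membered aromatic ring with 2 nitrogen, ortho to a large group, two atoms from the ring nitrogen, para to a large group, as set out in methyl in place of fluoro on an aromatic carbon

In compound 4 the change sits on a six-membered aromatic ring of carbon only, part of a fused system of two rings, meta and para to a fused ring; so it is the same kind of change, not the same change. The difference between the cores of compound 3 and compound 2 is not broken down here.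

The step from compound 2 to compound 1 could only be bounded because compound 2 sits at the limit of > 50000 nM in this assay, at which 1 of the 3 values shown sits. For compound 4 the step from compound 3 is expected to be small, within the scatter, namely a 1.1-fold higher number from compound 3 to compound 4 (0.04 log units; within the scatter). Compound 4 is therefore expected to give about 1000 nM in this assay, between 300 nM and 3500 nM.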

Compound 4, half-maximal inhibitory concentration: 1640 nM
Compound 4: the middle estimate sits 1.6-fold (0.21 log units) below what was measured, and the stated range covers the measured number.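

In this assay, methyl in place of fluoro on the six-membered aromatic ring of carbon only gave a 1.8-fold higher number from compound 3 to compound 4 (0.25 log units; within the scatter), so on the core of compound 3 the change stays within the scatter of repeated measurements. The change therefore does not carry over from one core to the other with the same outcome, as the two steps stand further apart than their combined scatter allows: the same change on two cores in this assay, an at least 3.7-fold lower number (0.57 log units; beyond the scatter) from compound 2 to compound 1 and a 1.8-fold higher number (0.25 log units; within the scatter) from compound 3 to compound 4, at least 6.6-fold (0.82 log units) apart, beyond the scatter of two such steps. Among these compounds, this rests on only two pairs, on different rings, and it does not show which feature of the cores separates the results, while the earlier step remains only a bound, with compound 2 standing at a limit of the assay and not at a number: the limit of > 50000 nM in this assay, at which 1 of the 4 values shown sits.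

The compounds shown leave open whether the small step from fluoro to methyl would hold at another carbon of the same ring, or on a further core carrying the same aminosulfonyl-free or sulfonamide side. They also leave open how a larger or different group at this place, such as an amine, a nitrile or a longer chain, would read in this assay.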